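The source may hold more compounds than are shown below. What is called first, only, known or untested is meant among the compounds shown, and "the series" means these compounds.

Compound 1, `Cc1n[nH]cc1-c1cccc2c1CCC2c1ncc[nH]1`, gives 3 nM in a functional assay on CHO cells for agonist activity at Alpha-1A adrenergic receptor (Homo sapiens), read by FLIPR and calcium flux; a higher number here means that more compound is needed for the effect, a lower number that less compound is needed.
Compound 2, `Cn1ccc(-c2cccc3c2CCC3c2ncc[nH]2)n1`, gives > 1300 nM in this assay, which is a limit of the assay and not a number.
Compound 3, `Cn1cc(-c2cccc3c2CCC3c2ncc[nH]2)cn1`, gives > 2900 nM in this assay, again a limit of the assay and not a number.

Of the three values shown, compound 3 stands at a limit, so all that is known is that it needs more compound than the assay could resolve; one further value shown is also a limit. The step to compound 4, `CNC(=O)c1cccc2c1CCC2c1ncc[nH]1`, is methylcarbamoyl in place of 1-methyl-1H-pyrazol-4-yl on an aromatic carbon. Within the data shown here, no measured step exchanges a pyrazolyl for an amide, so the comparison is indirect. Among the measured compounds shown here, the steps that bear on it are an at least 430-fold higher number from compound 1 to compound 2 (2.63 log units; beyond the scatter) and an at least 960-fold higher number from compound 1 to compound 3 (2.98 log units; beyond the scatter); both show that altering the group at this position moved the number a long way. The step that the two limits leave unreadable from compound 2 to compound 3 cannot be read because both ends are limits. Since compound 3 sits at a limit, the step to compound 4 is expected to be downward but of uncertain size, an at least 5.8-fold lower number from compound 3 to compound 4 (0.76 log units; beyond the scatter). In this assay compound 4 is estimated at 500 nM, with a range from 30 nM to 5000 nM, and a real chance that only a limit is reported.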

Compound 4, half-maximal effective concentration: 2200 nM
Estimate against measurement, compound 4: 4.4-fold (0.64 log units) below; the range from low to high includes it.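

In this assay compound 3 gives > 2900 nM, which is a limit of the assay and not a number, and the change from its 1-methyl-1H-pyrazol-4-yl to methylcarbamoyl reads only as an at least 1.3-fold lower number from compound 3 to compound 4 (0.11 log units; that floor lies within the scatter), so this result does not establish a real gain. What is new is that a group with no ring and with a hydrogen-bond donor yields an actual number at this aromatic carbon, yet that number still leaves a wide gap: a 730-fold higher number from compound 1 to compound 4 (2.87 log units; beyond the scatter). Among the four compounds, only the 3-methyl-1H-pyrazol-4-yl group of compound 1 gives a low number here, and compound 2, compound 3 and compound 4 all stand far from it, whether the replacing group carries a ring or not.

From the compounds shown here alone, the step from compound 2 to compound 4 cannot be read, so it remains open whether methylcarbamoyl truly differs from the 1-methyl-1H-pyrazol-3-yl group. Going by these compounds, it also remains open how a plain 1H-pyrazol-4-yl without its methyl, a primary amide, an amine or a carboxylic acid would fare at this position.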